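This account rests on a few compounds, and the source may have more. Where it says the series, first, only, none or still open, it means among the compounds named here.

Measured compounds:
- compound 1, `O=S(=O)(CC1=NCCO1)C1C(c2ccc(Cl)cc2)=NOC1c1ccc(Cl)cc1`: "not active" (no number reported)
- compound 2, `COc1ccc(C2=NN(c3ccccc3)C(c3ccc(C)cc3)C2S(=O)(=O)CC2=NCCO2)cc1`: 62.5%
- compound 3, `COc1ccc(C2=NN(c3ccccc3)C(c3ccc(C)cc3)C2S(=O)(=O)CC2=NCCS2)cc1`: 42.6%

In a functional assay, tested at 50 ug/mL (on this read-out higher numbers stand for a stronger effect at the one concentration tested and lower numbers for a weaker effect), compound 1 is reported as "not active" (no number reported), with no number given. Compound 2 and compound 3 share a core that differs from that of compound 1, and this difference between the two cores is not broken down here. Compound 3 differs from compound 2 only by a group of 5 heavy atoms (3 carbon, 1 nitrogen, 1 sulfur; one five-membered non-aromatic ring with 2 hetero atoms) in place of a group of 5 heavy atoms (3 carbon, 1 nitrogen, 1 oxygen; one five-membered non-aromatic ring with 2 hetero atoms), on a saturated chain carbon bound to a sulfonyl sulfur, and that change gave a number 19.9 percentage points lower from compound 2 to compound 3 (beyond the scatter). The same kind of change, (a group of 5 heavy atoms (3 carbon, 1 nitrogen, 1 sulfur; one five-membered non-aromatic ring with 2 hetero atoms) in place of a group of 5 heavy atoms (3 carbon, 1 nitrogen, 1 oxygen; one five-membered non-aromatic ring with 2 hetero atoms), on a saturated chain carbon bound to a sulfonyl sulfur), turns compound 1 into the untested compound 4, `O=S(=O)(CC1=NCCS1)C1C(c2ccc(Cl)cc2)=NOC1c1ccc(Cl)cc1`. Within the data shown here, since compound 1 shows no measurable effect in this assay, and the one recorded step of this change lowered the read-out rather than raising it, compound 4 is expected to stay weak, around 5%, likely between 0% and 20%.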

Compound 4, a percentage reported as activity, at one concentration (the size of the read-out at that concentration, not a potency): "not active" (no number reported)
The entry for compound 4 holds no number; no gap can be computed for the estimate.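

Compound 1 and compound 4 both lack a number in this assay, so no step can be read between them. As far as these compounds go, whether this ring change alters the read-out on the core of compound 1 stays open, and no supporting measurement bears on this result.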